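Swapping methyl for chloro on a growth inhibitor

The source may report more compounds than this note shows. Statements on the series, on what has been measured and on what is new or still open speak of the compounds shown alone.

Measured so far in a functional assay on A-375 cells (Homo sapiens) for inhibition, read by CCK-8 assay, with a stated time of 72 h, tested at 8 uM; on this read-out higher numbers stand for more inhibition of growth at the one concentration tested and lower numbers for less inhibition of growth:
Compound 1 `Cc1ccc(SCc2ccc(C(=O)Nc3ccccc3N)cc2)cc1` gives 67%
Compound 2 `Nc1ccccc1NC(=O)c1ccc(CSc2nccc(C(F)(F)F)n2)cc1` gives 80.1%

Compound 1 holds the lower of these two numbers, and the gap up to compound 2 lies beyond the usual scatter of repeated measurements. The next molecule is compound 3 `Nc1ccccc1NC(=O)c1ccc(CSc2ccc(Cl)cc2)cc1` which differs from compound 1 in a single place: chloro in place of methyl on an aromatic carbon with chloro in place of methyl on an aromatic carbon, so that 4-methylphenyl becomes 4-chlorophenyl. Going by the values given here, no measured pair shows this swap, so the only anchor is compound 1 at 67% on the same scale. In this assay no step beyond the scatter is expected. The expected change is small (a number 3 percentage points higher from compound 1 to compound 3 (within the scatter)) and has no firm direction. The estimate for compound 3 is 70% with an expected range from 55% to 84% on this scale.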

Compound 3, percent growth inhibition at one concentration: 48.6%
Estimate against measurement, compound 3: 21.4 percentage points above, and the stated range ends above it.
By their numbers in this assay, from the lowest: compound 3; then compound 1; then compound 2.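

In this assay, going by these compounds alone, the swap of methyl for chloro gives a number 18.4 percentage points lower from compound 1 to compound 3 (beyond the scatter) and so shows for the first time that this position responds to a single change, since compound 1 and compound 2 differ in more than one place. The change is small on paper: one heavy atom replaces another on an aromatic carbon para to a large group, while the counts of hydrogen-bond donors and acceptors and the net charge stay the same. Nothing here explains the drop.

This single pair cannot show how other groups at this position, such as methoxy or an amine, would compare with methyl and chloro. It also leaves open whether the same swap would have a similar effect on a different core.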